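Aryl swap on the shared core: compound 4 expected weak

This account rests on a few compounds, and the source may have more. Where it says the series, first, only, none or still open, it means among the compounds named here.

In a functional assay on U-87MG ATCC cells for inhibition, with U-87 MG (Homo sapiens) as the target, read by MTT assay, with a stated time of 72 h (a higher number here means a weaker inhibitor, a lower number a stronger inhibitor), compound 3 `COc1ccc(C(Nc2cc(C)ccn2)c2ccc3cccnc3c2O)cc1O` returns only a limit of the assay, > 10000 nM. Compound 2 `Cc1ccnc(NC(c2ccccc2C)c2ccc3cccnc3c2O)c1` also returns only a limit in this assay, > 10000 nM. Compound 1 `Cc1ccnc(NC(c2ccc3cccnc3c2O)c2c(F)cccc2Cl)c1` is the single member with a number, giving 20600 nM in this assay, so no compound shown is a strong inhibitor. The steps touching compound 3, a step that the limit leaves unreadable from compound 1 to compound 3 and a step that the two limits leave unreadable from compound 2 to compound 3, cannot be read, and neither can a step that the limit leaves unreadable from compound 1 to compound 2; the limit of > 10000 nM in this assay, at which 2 of the 3 values shown sit, is where readable information ends.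

Compound 4 `Cc1ccnc(NC(c2cccc(F)c2)c2ccc3cccnc3c2O)c1` differs from compound 3 by 3-fluorophenyl in place of 3-hydroxy-4-methoxyphenyl on a saturated chain carbon bound to an aromatic carbon and a nitrogen on an aromatic ring. The nearest measured comparison is compound 1, whose 2-chloro-6-fluorophenyl group on the same saturated chain carbon gives 20600 nM in this assay, weak but numbered. No step beyond the scatter is expected in this assay for compound 4, with a limit the most likely outcome. Compound 4 is therefore estimated at 20000 nM, within 8000 nM to 60000 nM. The step that the limit leaves unreadable from compound 3 to compound 4 implied by this estimate is expected to remain unreadable against the limit of compound 3.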

Compound 4, half-maximal inhibitory concentration: 9200 nM
Compound 4: the middle estimate sits 2.2-fold (0.34 log units) above what was measured; measured number inside the range.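

In this assay, for the compounds shown here, the 3-fluorophenyl group on the saturated chain carbon bound to an aromatic carbon and a nitrogen on an aromatic ring gives the first readable change at this position: a 2.2-fold lower number from compound 1 to compound 4 (0.35 log units; beyond the scatter). Against the two limits only floors can be stated, an at least 1.0-fold lower number from compound 3 to compound 4 (0.03 log units; that floor lies within the scatter) and an at least 1.0-fold lower number from compound 2 to compound 4 (0.03 log units; that floor lies within the scatter), so neither comparison fixes the size of a change. Going by these compounds alone, the earlier steps among compound 1, compound 2 and compound 3 cannot be read, so the comparison with compound 1 carries the only sized change at this position.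

From the compounds shown here alone, it remains open whether an unsubstituted phenyl or a 3-chlorophenyl group at this position would give a number close to that of compound 4. Also open, going by these compounds, is how a phenyl ring carrying an amine or a carboxylic acid would read out here.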